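Swapping a Trifluoromethoxy Group for Methoxy

A few compounds are considered here, and "the series" means these few. Any claim that something is new, unique, unknown or untested is made for them only; others in the source may bear on it.

Of the compounds shown here, three built on one shared core have been tested in a functional assay on A549 cells (Homo sapiens) for cytotoxicity, read by MTT assay, with a stated time of 24 h; a higher number here means a weaker inhibitor, a lower number a stronger inhibitor. Compound 1 `FC(F)(F)Oc1ccc(-c2cc(COc3ccccc3-c3nc4ccccc4s3)on2)cc1` gives 23900 nM. Compound 2 `c1ccc(-n2cc(COc3ccccc3-c3nc4ccccc4s3)nn2)cc1` gives 16400 nM, and compound 3 `FC(F)(F)C(F)(F)C(F)(F)C(F)(F)C(F)(F)C(F)(F)C(F)(F)C(F)(F)CCn1cc(COc2ccccc2-c2nc3ccccc3s2)nn1` gives 13100 nM. Compound 1 returns the largest of these numbers, yet its gaps to compound 2 and compound 3 both fall within the usual scatter of this assay, so none of the three can be called weaker or stronger than another.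

Compound 4 `COc1ccc(-c2cc(COc3ccccc3-c3nc4ccccc4s3)on2)cc1` has not yet been measured. It differs from compound 1 by methyl in place of trifluoromethyl on an oxygen on an aromatic ring. Among the compounds with values here, no measured pair shows this change, so the expectation is a step no larger than the scatter, in no clear direction. Compound 4 is expected to give about 20000 nM, between 8000 nM and 50000 nM, an estimated step of a 1.2-fold lower number from compound 1 to compound 4 (0.08 log units; within the scatter).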

Compound 4, half-maximal inhibitory concentration: 24100 nM
The estimate for compound 4 lay 1.2-fold (0.08 log units) below the measured number; the range from low to high includes it.
By their numbers in this assay, from the lowest: compounds 3, 2, 1 and 4 (each within the scatter of the next).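

Swapping trifluoromethyl for methyl on an oxygen on an aromatic ring gives a 1.0-fold higher number from compound 1 to compound 4 (0.00 log units; within the scatter) in this assay, the first direct reading of this change. On this core, then, trifluoromethoxy and methoxy cannot be told apart in this assay. No measured evidence here bears on why the step is so small.

From the compounds shown here alone, whether an amine or a carboxylic acid in place of methoxy would move the number beyond the scatter remains open. So does whether the same swap would behave alike on a different core.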